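The source may hold more compounds than are shown below. What is called first, only, known or untested is meant among the compounds shown, and "the series" means these compounds.

Measured so far in a functional assay on A549 cells (Homo sapiens) for antiproliferative activity, read by MTT assay, with a stated time of 48 h; a lower number here means a stronger inhibitor, a higher number a weaker inhibitor:
compound 1 `CCCC(C)Oc1ccc(C(=O)/C=C/c2c(/C=C/c3ccc(OC)cc3)cc(OC)cc2OC)cc1`: 9.4 ug/mL
compound 2 `COc1ccc(/C=C/c2cc(OC)cc(OC)c2/C=C/C(=O)c2ccc(Br)cc2)cc1`: 8.3 ug/mL
compound 3 `COc1ccc(/C=C/c2cc(OC)cc(OC)c2/C=C/C(=O)c2ccc(-c3ccccc3)cc2)cc1`: 4.6 ug/mL

Compound 1 gives the highest number of the three in this assay, and the steps away from it are small: a 1.1-fold lower number from compound 1 to compound 2 (0.05 log units; within the scatter); a 2.0-fold lower number from compound 1 to compound 3 (0.31 log units; beyond the scatter). The two other compounds sit close to each other as well: a 1.8-fold lower number from compound 2 to compound 3 (0.26 log units; within the scatter).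

Compound 4 `CCN(CC)c1ccc(C(=O)/C=C/c2c(/C=C/c3ccc(OC)cc3)cc(OC)cc2OC)cc1` differs from compound 1 in one place: diethylamino in place of 1-methylbutoxy on an aromatic carbon. The two measured steps that replace the 1-methylbutoxy group at the same place bear on this; one stays level and one is a modest move to a lower number. A small downward step in this assay is therefore expected for compound 4, roughly a 1.3-fold lower number from compound 1 to compound 4 (0.13 log units; within the scatter), quite possibly within the scatter. The estimate for compound 4 is 7 ug/mL, with a range from 3.5 ug/mL to 14 ug/mL.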

Compound 4, half-maximal inhibitory concentration: 5.4 ug/mL
Compound 4: the middle estimate sits 1.3-fold (0.11 log units) above what was measured, within the range that was stated.
By their numbers in this assay, from the lowest: compounds 3, 4, 2 and 1 (each within the scatter of the next, the first and the last beyond it).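

In this assay, diethylamino at this aromatic carbon reads level with 1-methylbutoxy (a 1.7-fold lower number from compound 1 to compound 4 (0.24 log units; within the scatter)), with phenyl (a 1.2-fold higher number from compound 3 to compound 4 (0.07 log units; within the scatter)) and with bromo (a 1.5-fold lower number from compound 2 to compound 4 (0.19 log units; within the scatter)). Compound 4 therefore adds a nitrogen-bearing group to the series and lies within the scatter of all three earlier compounds, although compound 1 and compound 3 remain separated by more than the scatter. Nothing available explains where compound 4 falls.

From the compounds shown here alone, a carboxylic acid or an unsubstituted amine at this carbon remains open. So does any change elsewhere on the shared core.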